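The source may hold more compounds than are shown below. What is called first, only, known or untested is meant among the compounds shown, and "the series" means these compounds.

Measured compounds:
Compound 1, `Oc1ccc(OC(=S)Nc2ccc(Nc3ccc(C(F)(F)F)cc3)cc2)cc1`: 6.04
Compound 2, `CC(=O)Nc1ccc(OC(=S)Nc2ccc(Oc3ccc([N+](=O)[O-])cc3)cc2)cc1`: 4.81
Compound 3, `O=[N+]([O-])c1ccc(Nc2ccc(NC(=S)Oc3ccc(O)cc3)cc2)cc1`: 4.54

Three compounds have been run in a physicochemical assay for lipophilicity; a lower number here means a more polar compound, a higher number a more lipophilic compound. Compound 1 gives 6.04 in this assay, compound 3 gives 4.54, and compound 2 gives 4.81. Compound 3 and compound 1 differ in one place, (trifluoromethyl in place of nitro on an aromatic carbon), and this change carries a number 1.50 log units higher from compound 3 to compound 1 (beyond the scatter). The values of compound 2 and compound 3 lie within the scatter of each other, so nothing can be read from their order. Among the measured compounds shown here, compound 1 sits beyond the scatter from compound 2, but no single step joins these two.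

Compound 4, `CC(=O)Nc1ccc(OC(=S)Nc2ccc(Oc3ccc(C(F)(F)F)cc3)cc2)cc1`, has not yet been measured in this assay. It differs from compound 2 in one place, (trifluoromethyl in place of nitro on an aromatic carbon). The difference between the core of compound 2 and the core of compound 3 is not broken down here. For the measured compounds named here, the change from compound 2 to compound 4 is the same change as the one from compound 3 to compound 1, made at a place described in the same words.

Because that change gave a number 1.50 log units higher from compound 3 to compound 1 (beyond the scatter), the step from compound 2 to compound 4 in this assay is expected to be about as large, a number 1.49 log units higher from compound 2 to compound 4 (beyond the scatter). This rests on one pair only, compound 3 and compound 1, and the two cores are not the same, so the expectation is loose. Compound 4 is accordingly estimated at 6.3 in this assay, with a likely span from 5.7 to 6.9.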

Compound 4, partition coefficient: 5.41
Compound 4: middle estimate off by 0.89 log units, on the high side; measured number below the stated range.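

In this assay, trifluoromethyl in place of nitro on an aromatic carbon gives a number 0.60 log units higher from compound 2 to compound 4 (beyond the scatter), while the same change in the other core gives a number 1.50 log units higher from compound 3 to compound 1 (beyond the scatter). In these two pairs, the only ones available, the direction of the change carried from one core to the other and both steps lie beyond the scatter, but the size did not carry, so a step read in one of these cores was a guide to its sign and not to its magnitude in the other. The pairs do not show which of the differences between the two cores goes with the smaller step, or whether any single one does, and nothing measured here bears on why the steps differ in size.

The compounds shown leave open how a nitrile, an amine or a carboxylic acid on that same aromatic carbon would stand against nitro and trifluoromethyl in either core. They also leave open whether the direction seen in these two pairs would hold in a third core, and how large the step would be there.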